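This account rests on a few compounds, and the source may have more. Where it says the series, first, only, none or still open, it means among the compounds named here.

Among the measured compounds shown here, compound 1, with the structure `CCOC(=O)CSc1nncc2cnc(C)n12`, is the only member of this small set with a definite number: in a functional assay for inhibition, with Homo sapiens as the target (on this read-out lower numbers stand for stronger inhibition and higher numbers for weaker inhibition), compound 1 gives 52000 nM. Compound 2, `CCOC(=O)CSc1nncc2c(C)nc(C)n12`, carries a methyl in place of hydrogen on an aromatic carbon; this difference is methyl in place of hydrogen on an aromatic carbon. For compound 2 in this assay only a limit is reported, > 48000 nM. The step that the limit leaves unreadable from compound 1 to compound 2 therefore cannot be read in size, because the limit of > 48000 nM in this assay, at which 2 of the 3 values shown sit, caps what the measurement can show.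

Compound 3, `CCCc1nc(C)c2cnnc(SC)n12`, has a different core; the difference between the two cores is not broken down here. For compound 3 too this assay returns only a limit, > 48000 nM.

Compound 4, `CCCc1nc(C)c2c(C)nnc(SC)n12`, is not yet measured. Relative to compound 3 it is the same kind of change as that from compound 1 to compound 2, a methyl in place of hydrogen on an aromatic carbon, described as methyl in place of hydrogen on an aromatic carbon. The surroundings differ, though: here the carbon lies in a six-membered aromatic ring with 3 nitrogen, ortho to a fused ring and para to a methylsulfanyl group, whereas in compound 2 it lies in a five-membered aromatic ring with 2 nitrogen, two ring bonds from the ring atom that bears a methyl group.

Since compound 3 is already at a limit with > 48000 nM, and the earlier methyl step is unreadable, compound 4 is expected to stay weak, with an expected step that the limit leaves unreadable from compound 3 to compound 4. The estimate for compound 4 in this assay is 90000 nM, between 30000 nM and 300000 nM.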

Compound 4, half-maximal inhibitory concentration: > 48000 nM
Compound 4: no number, only a limit; the forecaster's own chance of this, stated with the estimate: 85%; the middle value lies beyond the limit too.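

In this assay, compound 4 returns only a limit, as compound 3 does, and no new step can be read between them because of that limit: the limit of > 48000 nM in this assay, at which 3 of the 4 values shown sit.

With compound 1 the only one carrying a definite number, the compounds shown leave open whether a methyl in place of hydrogen on an aromatic carbon changes inhibition in either core, and how far compound 2, compound 3 and compound 4 lie beyond their limits.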